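A few compounds are considered here, and "the series" means these few. Any claim that something is new, unique, unknown or untested is made for them only; others in the source may bear on it.

Working notes on the methylphenyl series. The three compounds share one core, a hydroxamic acid chain and an arylamino group, and differ only in where the methyl sits on that aryl ring. Compound 1 `Cc1ccccc1Nc1c(NCCCCCC(=O)NO)c(=O)c1=O` has been run in an ADME assay on cells (Hepatocyte, Homo sapiens) for pharmacokinetics, read by LC-MS, with a stated time of 90 min, tested at 1 uM (a higher number here means faster removal of the compound, a lower number slower removal), and gives < 5 uL/min, which is a limit of the assay rather than a number. Compound 2 `Cc1cccc(Nc2c(NCCCCCC(=O)NO)c(=O)c2=O)c1` gives 18 uL/min in this assay. Going by the values given here, compound 2 therefore holds the only actual number in the set; the other value sits at the limit (the limit of < 5 uL/min in this assay, at which 1 of the 2 values shown sits). Among the compounds with values here, the single measured step, an at least 3.6-fold higher number from compound 1 to compound 2 (0.55 log units; beyond the scatter), runs from that limit to the number for compound 2, so only its lower bound is fixed.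

Compound 3 `Cc1ccc(Nc2c(NCCCCCC(=O)NO)c(=O)c2=O)cc1` is not yet measured in this assay. It differs from compound 2 as follows: 4-methylphenyl in place of 3-methylphenyl on a nitrogen on an aromatic ring. Within the data shown here, the only step that bears on this change is an at least 3.6-fold higher number from compound 1 to compound 2 (0.55 log units; beyond the scatter); it shows that moving the methyl around the ring can shift the readout in this assay by a modest amount at least, but it does not show which way a further move will go. Compound 3 is expected to give about 20 uL/min in this assay, in a range from 8 uL/min to 50 uL/min. The expected step of a 1.1-fold higher number from compound 2 to compound 3 (0.05 log units; within the scatter) is estimated to stay within the scatter.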

Compound 3, intrinsic clearance in a liver preparation (reported as CLH), per the amount of preparation that the assay uses: 7.2 uL/min
Estimate against measurement, compound 3: 2.8-fold (0.44 log units) above; measured number outside the range, below it.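

Moving the methyl from 3-methylphenyl to 4-methylphenyl is not neutral in this assay: the data give a 2.5-fold lower number from compound 2 to compound 3 (0.40 log units; beyond the scatter), so the readout also separates these two placements, not only those of the 2-methylphenyl and 3-methylphenyl compounds. Compound 2 now stands apart from both other compounds with the highest number of the three, so the readout does not climb steadily through the 2-methylphenyl, 3-methylphenyl and 4-methylphenyl compounds, while the remaining comparison gives only an at least 1.4-fold higher number from compound 1 to compound 3 (0.15 log units; that floor lies within the scatter). That step fixes a floor and no more, and compound 3 cannot be firmly placed relative to compound 1, as the value of compound 1 is a limit of the assay: the limit of < 5 uL/min in this assay, at which 1 of the 3 values shown sits.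

As far as these compounds go, the actual number for compound 1 stays open, and with it the size of both steps that start from it. Also open, from the compounds shown here alone, is whether the same dependence on placement holds for a different group on the aryl ring, such as methoxy or chlorine, or for the same three aryl groups on a shorter or longer chain bearing the hydroxamic acid.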